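Extending the Chain Once More on the Shared Core

The source may report more compounds than this note shows. Statements on the series, on what has been measured and on what is new or still open speak of the compounds shown alone.

In a functional assay, with a stated time of 30 min (on this read-out higher numbers stand for weaker inhibition and lower numbers for stronger inhibition), compound 1 `CCCCCCCCCCOc1cc(OC)ccc1C(C)=O` gives 40100000 nM. Compound 2 `CCCCCCCCCCCCOc1cc(OC)ccc1C(C)=O` gives 37400000 nM, so the two stand level within the usual scatter. Compound 3 `CCCCCCCCCCCCCCCCOc1cc(OC)ccc1C(C)=O` differs from compound 2 by butyl in place of hydrogen on a saturated chain carbon, ten or more bonds along the chain from an oxygen on an aromatic ring. Among the compounds with values here, only one measured step bears on this change: a 1.1-fold lower number from compound 1 to compound 2 (0.03 log units; within the scatter), which put ethyl in place of hydrogen at the same kind of place. Going by that single step, which is thin support, the expected change in this assay is a 1.1-fold lower number from compound 2 to compound 3 (0.03 log units; within the scatter), with nothing beyond the scatter. Compound 3 is estimated at 35000000 nM, with an expected range of 15000000 nM to 80000000 nM.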

Compound 3, half-maximal inhibitory concentration: 39400000 nM
For compound 3 the middle estimate is 1.1-fold (0.05 log units) below the measured one; low and high end bracket the measured number.
By their numbers in this assay, from the lowest: compounds 2, 3 and 1 (each within the scatter of the next).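

Butyl in place of hydrogen at this place on the chain gives a 1.1-fold higher number from compound 2 to compound 3 (0.02 log units; within the scatter), and hexyl in place of hydrogen gives a 1.0-fold lower number from compound 1 to compound 3 (0.01 log units; within the scatter) in this assay. Both steps lie within the scatter, so across compounds 1, 2 and 3 even the largest addition shown leaves the number level, as the ethyl step did. No measurement here offers an explanation for this flat result. Still open, going by these compounds, is whether a shorter chain such as butyl, or a chain carrying an amine or a carboxylic acid, would move the number in this assay.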